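The source may hold more compounds than are shown below. What is called first, only, known or untested is meant among the compounds shown, and "the series" means these compounds.

In a functional assay on NALM-6 cells (Homo sapiens) for cytotoxicity, with a stated time of 72 h (a higher number here means that more compound is needed for the effect, a lower number that less compound is needed), compound 1 `C=C[C@@](C)(/C=C/c1ccc(OCc2ccccc2)cc1)CCC=C(C)C` gives only a limit, > 43400 nM. Compound 2 `C=C[C@@](C)(/C=C/c1ccc(O)cc1)CC/C=C(C)/C=N/N` also gives only a limit, > 43400 nM. For the measured compounds named here, compound 3 `C=C[C@@](C)(/C=C/c1ccc(O)c(/C=C/C(=O)c2ccccc2)c1)CCC=C(C)C` gives 4470 nM, the only actual number among the three measured compounds, so it is the single firm reference point in this small set.

The next compound, compound 4 `C=C[C@@](C)(/C=C/c1ccc(O)c(/C=C/C(=O)O)c1)CCC=C(C)C`, differs from compound 3 at one place: hydroxy in place of phenyl on a carbonyl carbon. In words, hydroxy stands in place of phenyl on a carbonyl carbon, which turns benzoyl into carboxy.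

Going by the values given here, no two measured compounds differ at just one place, so the data offer no measured step to use as a guide, and any forecast here is a rough one. Among the compounds with values here, compound 3, at 4470 nM, is the only measured compound that carries the benzoyl group, and that is the group lost in this change. A clear loss of potency is therefore expected, meaning a higher number in this assay, and compound 4 may well give only a limit.

The expected step, as estimated, is a 5.4-fold higher number from compound 3 to compound 4 (0.73 log units; beyond the scatter). For compound 4 the estimated value is 24000 nM, with an expected range of 10000 nM to 43400 nM.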

Compound 4, half-maximal effective concentration: > 43400 nM
Compound 4: a limit, no number (the forecaster's own chance of this, stated with the estimate: 55%); middle value at least 1.8-fold (0.25 log units) away from the limit.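

For the compounds shown here, this is the first measured step in the set, and it shows that the group on this carbonyl carbon matters in this assay: with benzoyl turned into carboxy, the change gives an at least 9.7-fold higher number from compound 3 to compound 4 (0.98 log units; beyond the scatter). Keeping the carbonyl and its double-bonded chain carbon is therefore not enough to retain a measurable value, and among the compounds shown, only compound 3, with its phenyl at this place, gives an actual number. The step can be stated only as a lower bound, because compound 4 gives a limit rather than a number, and the same limit applies to most of the set: the limit of > 43400 nM in this assay, at which 3 of the 4 values shown sit.

The compounds shown cannot tell whether the phenyl ring itself is needed or whether another carbon group on the carbonyl, such as a methyl or a cyclohexyl, would serve as well. On these data alone, it also remains open whether a methyl ester or an amide would restore any of the effect lost with the carboxy group, and whether a phenyl ring bearing a chlorine or a methoxy group would improve on compound 3 at 4470 nM.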